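The compounds below may be only part of what the source reports. "The series", "measured", "known", "first", "only" and "open" are said of these compounds alone.

Compound 1 `O=C(NO)c1ccc(CNc2nccc(-c3cccnc3)n2)cc1` carries the hydroxamic acid, and in an assay for inhibition of histone deacetylase 8 (Homo sapiens), read by fluorescence, with stated times of 15 min and 60 min (a lower number here means a stronger inhibitor, a higher number a weaker inhibitor), compound 1 gives 410 nM. Compound 2 `Nc1cc(O)ccc1NC(=O)c1ccc(CNc2nccc(-c3cccnc3)n2)cc1` replaces that hydroxy with the 2-amino-4-hydroxyphenyl amide. In this assay compound 2 reaches only a limit, > 20000 nM, which is the limit of > 20000 nM in this assay, at which 1 of the 3 values shown sits. Going by the values given here, that change is the one measured step bearing here: an at least 48-fold higher number from compound 1 to compound 2 (1.68 log units; beyond the scatter). Compound 3 `Nc1ccccc1NC(=O)c1ccc(CNC2=NC(=O)C(Cc3ccccc3)N2)cc1`, an aminophenyl amide on a different core, gives 13000 nM in this assay. Compound 4 `CC(C)(C)[Si](C)(C)OCc1ccc(NC(=O)c2ccc(CNc3nccc(-c4cccnc4)n3)cc2)c(N)c1` differs from compound 2 by a group of 9 heavy atoms (7 carbon, 1 oxygen, 1 silicon; no ring) in place of one oxygen atom, on an aromatic carbon, a group of 9 heavy atoms in place of one oxygen atom, on an aromatic carbon. Among the compounds with values here, no measured step covers a change of this kind; the anchors are the limit of compound 2 and the weak value of compound 3. Compound 4 is therefore expected to remain weak in this assay, at about 15000 nM (range 4000 nM to 60000 nM). The implied step an at least 1.3-fold lower number from compound 2 to compound 4 (0.12 log units; that floor lies within the scatter) is an expectation only, measured against a limit.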

Compound 4, half-maximal inhibitory concentration: > 20000 nM
Compound 4 ended at the assay's limit (the forecaster's own chance of this, stated with the estimate: 50%); middle value at least 1.3-fold (0.12 log units) away from the limit.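

Compound 2 and compound 4 both stand at a limit, so no step can be read between them: the limit of > 20000 nM in this assay, at which 2 of the 4 values shown sit.

Still open, on these data alone, is how the group of 9 heavy atoms compares with hydroxy in this assay, since neither compound gives a value below the limit.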